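This account rests on a few compounds, and the source may have more. Where it says the series, first, only, none or still open, it means among the compounds named here.

Working notes on the series. Of the compounds shown here, two have numbers so far. In an assay on isolated protein for inhibition of Polyunsaturated fatty acid 5-lipoxygenase (Homo sapiens), read by HPLC, with stated times of 15 min and 10 min (on this read-out higher numbers stand for weaker inhibition and lower numbers for stronger inhibition), compound 1 `COC1=CC(=O)C(OC)=C(CCCCCCCCCCO)C1=O` gives 550 nM, while compound 2 `CCCCCCCCCCCCCc1c(O)c(O)cc(OC)c1OC` gives 28 nM in this assay. Compound 2 therefore stands at the lowest of the two numbers, and compound 1 sits at a higher number, beyond the scatter, so compound 2 is the stronger of the pair in this assay.

The next step goes from compound 2 to compound 3 `CCCCCCCCCCCCCc1c(O)c(O)cc(OC)c1O`. The change is hydrogen in place of methyl on an oxygen on an aromatic ring, that is, methoxy to hydroxy on the shared core. For the measured compounds named here, no step of this kind between measured compounds exists, so the size of the step is an open question. For compound 3 in this assay a step of a 1.3-fold lower number from compound 2 to compound 3 (0.10 log units; within the scatter) is expected, not beyond the scatter in either direction. Compound 3 is estimated at 22 nM in this assay, with a range from 7 nM to 70 nM.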

Compound 3, half-maximal inhibitory concentration: 1600 nM
Compound 3: middle estimate off by 73-fold (1.86 log units), on the low side; the whole stated range lies below it.
By their numbers in this assay, from the lowest: compound 2; then compound 1; then compound 3.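

In this assay, for the compounds shown here, methoxy to hydroxy on the shared core gives a 57-fold higher number from compound 2 to compound 3 (1.76 log units; beyond the scatter), the first step that differs in one place only. The methyl on this oxygen on an aromatic ring therefore matters: its replacement by hydrogen, with the loss of a single carbon, moves the number far beyond the scatter and weakens inhibition. Nothing available accounts for the size of this step.

The compounds shown leave open whether the loss follows from the missing methyl or from the hydroxy that enters, and an ethoxy or a fluorine at this place would help separate the two. Also open, on these data alone, is whether the other methoxy on the shared core would give a step of similar size on the same change.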